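The compounds below may be only part of what the source reports. "The series", "measured", "known", "first", "only" and "open" are said of these compounds alone.

Measured so far:
- compound 1, `O=C(Nc1ccc(Oc2ccnc3[nH]ccc23)cc1)c1cc2cccnc2n(-c2ccccc2)c1=O`: 290 nM
- compound 2, `O=C(Nc1ccc(Oc2ccnc3[nH]ccc23)cc1)c1cc2cccnc2n(-c2ccc(Br)cc2)c1=O`: 270 nM

In a functional assay on HT-29 cells (Homo sapiens) for antiproliferative activity, read by MTT assay, with a stated time of 72 h (on this read-out lower numbers stand for stronger inhibition and higher numbers for weaker inhibition), compound 2 gives 270 nM, the lowest of the two numbers shown, while compound 1 gives 290 nM. Among the compounds with values here, the only measured step, a 1.1-fold lower number from compound 1 to compound 2 (0.03 log units; within the scatter), lies within the scatter, so the two compounds cannot be told apart on this read-out.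

Compound 3, `COc1ccc(-n2c(=O)c(C(=O)Nc3ccc(Oc4ccnc5[nH]ccc45)cc3)cc3cccnc32)cc1`, is not yet measured. It differs from compound 2 in one place: methoxy in place of bromo on an aromatic carbon. Within the data shown here, the one step that bears on this position, a 1.1-fold lower number from compound 1 to compound 2 (0.03 log units; within the scatter), was too small to count. Among the measured compounds shown here, no measured step speaks for a methoxy group at this place. On that basis the change to compound 3 is expected to bring no step beyond the scatter in this assay. For compound 3 the estimated step is a 1.0-fold higher number from compound 2 to compound 3 (0.02 log units; within the scatter). Compound 3 is therefore expected to give about 280 nM, with a range from 120 nM to 650 nM.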

Compound 3, half-maximal inhibitory concentration: 1260 nM
For compound 3 the middle estimate is 4.5-fold (0.65 log units) below the measured one; measured number above the stated range.
By their numbers in this assay, from the lowest: compounds 2 and 1 (each within the scatter of the next); then compound 3.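

Unlike the bromo group, the methoxy group at this place, para to a large group, does register in this assay. The change from 4-bromophenyl to 4-methoxyphenyl gives a 4.7-fold higher number from compound 2 to compound 3 (0.67 log units; beyond the scatter), and methoxy in place of hydrogen gives a 4.3-fold higher number from compound 1 to compound 3 (0.64 log units; beyond the scatter). The position is therefore not indifferent to what it carries: hydrogen and bromo stay within the scatter of each other, while methoxy stands apart from both, on the side of weaker inhibition. No measurement is available that would explain why methoxy and bromo part ways here.

The three compounds leave open whether this weakening belongs to methoxy alone or extends to other groups attached through oxygen, such as hydroxy or ethoxy. They also leave open how an amine or a carboxylic acid would fare at this place.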